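The compounds below may be only part of what the source reports. "The series", "measured", "known", "first", "only" and "open" are said of these compounds alone.

Measured so far:
Compound 1 `Cc1c(OCCCCOc2cccc(C(=O)O)c2)ccc(C(=O)CC2CCCC2)c1O`: 99%
Compound 2 `Cc1ccc(C(=O)O)cc1OCCCCOc1ccc(C(=O)CC2CCCC2)c(O)c1C`: 100%

In an ADME assay on a cell-free system (plasma, Rattus norvegicus) for metabolic stability, read by LC-MS, with a stated time of 60 min, tested at 100 uM (a higher number here means that more of the compound is left, a lower number that less of the compound is left), compound 2 gives 100%, which lies within the usual scatter of compound 1 at 99%. The two compounds therefore stand level. Compound 3 `Cc1cc(OCCCCOc2ccc(C(=O)CC3CCCC3)c(O)c2C)ccc1C(=O)O` has the same atoms as compound 2, joined differently, with 4-carboxy-3-methylphenyl in place of 5-carboxy-2-methylphenyl on an oxygen on a saturated carbon. Within the data shown here, only one measured step bears on this change, a methyl in place of hydrogen on an aromatic carbon, and it shows a number 1 percentage points higher from compound 1 to compound 2 (within the scatter). Among the measured compounds shown here, with so small a step as the only guide, the expected result is a number 2 percentage points lower from compound 2 to compound 3 (within the scatter), so no real shift is expected beyond the scatter. Compound 3 is estimated at 98%, with an expected range of 88% to 100%.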

Compound 3, percent of the compound remaining: 114%
Compound 3: middle estimate off by 16 percentage points, on the low side; measured number outside the range, above it.
By their numbers in this assay, from the lowest: compounds 1 and 2 (each within the scatter of the next); then compound 3.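

In this assay, the arrangement of the groups on this ring makes a difference that the earlier step, a methyl in place of hydrogen, did not show. 4-carboxy-3-methylphenyl in place of 5-carboxy-2-methylphenyl, with the same atoms joined differently, gives a number 14 percentage points higher from compound 2 to compound 3 (beyond the scatter), and in place of 3-carboxyphenyl it gives a number 15 percentage points higher from compound 1 to compound 3 (beyond the scatter). No measurement here accounts for this shift. Still open, from the compounds shown here alone, is whether the shift would survive with an amide in place of the carboxylic acid, or with a longer chain on the oxygen.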